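The compounds below may be only part of what the source reports. "The series", "measured", "known", "first", "only" and "open" are said of these compounds alone.

Measured compounds:
compound 1 `C=CCc1ccc(OCc2cn(-c3ccccc3CO)nn2)c(O)c1`, 87.1%
compound 2 `C=CCc1cc(O)c(O)c(CN2CCC(CO)CC2)c1`, 49.4%
compound 3 `C=CCc1ccc(OCc2cn(-c3ccccc3Cl)nn2)c(O)c1`, 42.8%

In a functional assay on SK-N-SH cells (Homo sapiens) for inhibition, read by MTT assay, with a stated time of 72 h, tested at 50 uM (a higher number here means more inhibition of growth at the concentration tested, a lower number less inhibition of growth), compound 3 stands lowest of the three numbers; its gap to compound 2 lies within the scatter, while compound 1 lies beyond the scatter above it. Compound 4 `C=CCc1ccc(OCc2cn(-c3cccc(C#N)c3)nn2)c(O)c1` is not yet measured. It differs from compound 3 in one place: 3-cyanophenyl in place of 2-chlorophenyl on an aromatic nitrogen. For the measured compounds named here, only one measured step bears on this change, the exchange at the same place that gave a number 44.3 percentage points lower from compound 1 to compound 3 (beyond the scatter), a large drop. Going by the values given here, no measured pair exchanges a chloro for a nitrile, so the direction for compound 4 is uncertain. A modest change is expected, a number 7.2 percentage points higher from compound 3 to compound 4 (within the scatter), and compound 4 is therefore estimated at 50%, with a range from 25% to 80%.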

Compound 4, percent growth inhibition at one concentration: 78.8%
For compound 4 the middle estimate is 28.8 percentage points below the measured one; low and high end bracket the measured number.
By their numbers in this assay, from the lowest: compounds 3 and 2 (each within the scatter of the next); then compounds 4 and 1 (each within the scatter of the next).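

In this assay, for the compounds shown here, the earlier compounds showed only a drop at this position on the aromatic nitrogen, but a high number turns out not to depend on the 2-(hydroxymethyl)phenyl group. The 3-cyanophenyl group restores it (a number 36 percentage points higher from compound 3 to compound 4 (beyond the scatter)), and it stands close to the hydroxymethyl compound (a number 8.3 percentage points lower from compound 1 to compound 4 (within the scatter)). Nothing at hand explains this. The step changes both the group and its place on the phenyl ring, so 3-chlorophenyl and 2-cyanophenyl would be needed to separate the two. Going by these compounds, what an amine or a carboxylic acid would do here also stays open.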